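Methoxy for Fluoro at an Ortho Benzamide Position

This account rests on a few compounds, and the source may have more. Where it says the series, first, only, none or still open, it means among the compounds named here.

Measured compounds:
compound 1 `O=C(NO)c1ccc(CNC(=O)c2n[nH]cc2NC(=O)c2ccccc2Cl)cc1` 2400 nM
compound 2 `Nc1ccccc1NC(=O)c1ccc(CNC(=O)c2n[nH]cc2NC(=O)c2ccccc2F)cc1` 4800 nM
compound 3 `O=C(NO)c1ccc(CNC(=O)c2n[nH]cc2NC(=O)c2ccccc2F)cc1` 2200 nM

In a functional assay on HCT-116 cells (Homo sapiens) for inhibition, read by CCK-8 assay, with a stated time of 72 h (a lower number here means a stronger inhibitor, a higher number a weaker inhibitor), compound 2 gives 4800 nM, the high end of the three numbers; its value and that of compound 1 sit within the scatter of each other, while the step of a 2.2-fold lower number from compound 2 to compound 3 (0.34 log units; beyond the scatter) lies beyond it. Compound 4 `COc1ccccc1C(=O)Nc1c[nH]nc1C(=O)NCc1ccc(C(=O)Nc2ccccc2N)cc1` differs from compound 2 by methoxy in place of fluoro on an aromatic carbon. For the measured compounds named here, the only step touching this position, a 1.1-fold lower number from compound 1 to compound 3 (0.04 log units; within the scatter), swapped one halogen for another and changed nothing beyond the scatter. Going by the values given here, no measured step covers a methoxy here, so a step of a 1.0-fold higher number from compound 2 to compound 4 (0.02 log units; within the scatter) is expected, without a clear direction. Compound 4 is therefore estimated at 5000 nM, within 2000 nM to 12000 nM.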

Compound 4, half-maximal inhibitory concentration: 3680 nM
The estimate for compound 4 lay 1.4-fold (0.13 log units) above the measured number; measured number inside the range.
By their numbers in this assay, from the lowest: compounds 3, 1, 4 and 2 (each within the scatter of the next, the first and the last beyond it).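

The change from fluoro to methoxy gives a 1.3-fold lower number from compound 2 to compound 4 (0.12 log units; within the scatter) in this assay. For the compounds shown here, earlier, this position had only been compared between two halogens, so this is the first sign that a non-halogen group can sit here without moving the number beyond the scatter. No supporting measurement offers an explanation for this result.

Methoxy is seen here only with the 2-aminophenyl amide, so its effect in the hydroxy series remains open. An amine, a carboxylic acid or a longer chain such as ethoxy at this position also remains untested in the compounds shown.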